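Cyano in place of trifluoromethyl: working notes

This account rests on a few compounds, and the source may have more. Where it says the series, first, only, none or still open, it means among the compounds named here.

Values in an ADME assay on WI-38 cells (Homo sapiens) for cytotoxicity, read by MTT assay, with a stated time of 72 h; a lower number here means a stronger inhibitor, a higher number a weaker inhibitor:
- compound 1 `O=C(CCc1cccc2c1B(O)OC2)Nc1cccc(-c2ccc(F)cc2)c1`: 4100 nM
- compound 2 `O=C(CCc1cccc2c1B(O)OC2)Nc1cccc(-c2cccc(C(F)(F)F)c2)c1`: 23000 nM

Compound 2 holds the higher of the two numbers in this assay. Compound 3 `N#Cc1cccc(-c2cccc(NC(=O)CCc3cccc4c3B(O)OC4)c2)c1` differs from it by cyano in place of trifluoromethyl on an aromatic carbon, with cyano in place of trifluoromethyl on an aromatic carbon, meta to a large group. Within the data shown here, only one measured step bears on this change: a 5.6-fold higher number from compound 1 to compound 2 (0.75 log units; beyond the scatter). That step also exchanges a substituted phenyl group, but it involves different substituents, so it offers only a rough guide to size. A modest move to a lower number is expected, and the estimated step is a 1.9-fold lower number from compound 2 to compound 3 (0.28 log units; within the scatter). The estimate for compound 3 is 12000 nM, with an expected range of 4500 nM to 32000 nM.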

Compound 3, half-maximal inhibitory concentration: 7300 nM
Estimate against measurement, compound 3: 1.6-fold (0.22 log units) above; low and high end bracket the measured number.
By their numbers in this assay, from the lowest: compounds 1 and 3 (each within the scatter of the next); then compound 2.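

In this assay, among these compounds, the first direct reading for this substituent is a 3.2-fold lower number from compound 2 to compound 3 (0.50 log units; beyond the scatter) with cyano in place of trifluoromethyl, on an aromatic carbon meta to a large group. Trifluoromethyl therefore stands apart from cyano at this position. The comparison with the 4-fluorophenyl compound gives a 1.8-fold higher number from compound 1 to compound 3 (0.25 log units; within the scatter) and so does not separate 3-cyanophenyl from 4-fluorophenyl. No evidence available here bears on the origin of these differences.

From the compounds shown here alone, how an amine or a carboxylic acid on this aromatic carbon would compare with cyano remains open. Also open, going by these compounds, is whether the step from trifluoromethyl to cyano would hold on another core.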